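Cytotoxicity of a diarylpyrimidine series: from compound 3 to compound 4

A few compounds are considered here, and "the series" means these few. Any claim that something is new, unique, unknown or untested is made for them only; others in the source may bear on it.

Measured compounds:
compound 1, `COc1ccccc1-c1cc(C)c(Nc2ccnc(Nc3ccc(C#N)cc3)n2)c(C)c1`, 940 nM
compound 2, `Cc1cc(-c2cccc(C#N)c2)cc(C)c1Nc1ccnc(Nc2ccc(C#N)cc2)n1`, 920 nM
compound 3, `Cc1cc(-c2ccc(C(F)(F)F)cc2)cc(C)c1Nc1ccnc(Nc2ccc(C#N)cc2)n1`, 4160 nM

In an ADME assay on MT4 cells (Homo sapiens) for cytotoxicity, read by MTT assay, with a stated time of 4 days (a higher number here means that more compound is tolerated, a lower number that less compound is tolerated), compound 3 gives the highest number of the three. Its nearest neighbour is compound 1, with 940 nM, and compound 2 sits at 920 nM; the step of a 1.0-fold lower number from compound 1 to compound 2 (0.01 log units; within the scatter) lies within the scatter, so the two cannot be ordered. Against them, compound 3 stands apart: a 4.4-fold higher number from compound 1 to compound 3 (0.65 log units; beyond the scatter) and a 4.5-fold higher number from compound 2 to compound 3 (0.66 log units; beyond the scatter).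

Compound 4, `Cc1cc(-c2cccc(Cl)c2)cc(C)c1Nc1ccnc(Nc2ccc(C#N)cc2)n1`, differs from compound 3 in one place: 3-chlorophenyl in place of 4-(trifluoromethyl)phenyl on an aromatic carbon. The step that bears on it most directly is a 4.5-fold higher number from compound 2 to compound 3 (0.66 log units; beyond the scatter), which joins a 3-substituted phenyl ring to the 4-(trifluoromethyl)phenyl of compound 3. Compound 4 returns to a 3-substituted phenyl ring, so a step back toward the numbers of compound 1 and compound 2 is expected, though a chlorine is not a nitrile and the size is uncertain. Compound 4 is therefore expected to give 1800 nM in this assay, between 700 nM and 4500 nM, a step of a 2.3-fold lower number from compound 3 to compound 4 (0.36 log units; beyond the scatter).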

Compound 4, half-maximal cytotoxic concentration: 2160 nM
Beside the measured number, compound 4's estimate is 1.2-fold (0.08 log units) below it, and the stated range covers the measured number.
By their numbers in this assay, from the lowest: compounds 2 and 1 (each within the scatter of the next); then compounds 4 and 3 (each within the scatter of the next).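

With the step of a 2.3-fold higher number from compound 2 to compound 4 (0.37 log units; beyond the scatter) in this assay as the measure, a 3-substituted phenyl ring does not by itself fix the number at this position: chloro and cyano on that ring give results beyond the scatter of each other. The 3-chlorophenyl ring also stands apart from the 2-methoxyphenyl ring, by a 2.3-fold higher number from compound 1 to compound 4 (0.36 log units; beyond the scatter) but cannot be separated from the 4-(trifluoromethyl)phenyl ring, by a 1.9-fold lower number from compound 3 to compound 4 (0.28 log units; within the scatter) so compounds 3 and 4 now form a pair set off from compounds 1 and 2. No measurement shown here accounts for this grouping.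

On these data alone, whether the chlorine itself or its place on the ring matters more stays open. So does the number that a phenyl ring carrying an amine or a carboxylic acid would give in this assay at this position.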